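The compounds below may be only part of what the source reports. "The series", "measured", "known", "first", "only" and "open" are said of these compounds alone.

In a functional assay on MCF7 cells (Homo sapiens) for antiproliferative activity, read by MTT assay, with a stated time of 72 h (on this read-out lower numbers stand for stronger inhibition and higher numbers for weaker inhibition), compound 1 `Fc1ccc(-c2csc(N3N=C(c4ccc(N5CCCCC5)cc4)CC3c3ccc(Cl)cc3)n2)cc1` gives 23100 nM. Compound 2 `Clc1ccc(-c2csc(N3N=C(c4ccc(N5CCCCC5)cc4)CC3c3ccc(Cl)cc3)n2)cc1` is reported only as a limit of this assay, > 100000 nM, so its true number is not known (the limit of > 100000 nM in this assay, at which 1 of the 2 values shown sits). Among the measured compounds shown here, the single measured step, an at least 4.3-fold higher number from compound 1 to compound 2 (0.63 log units; beyond the scatter), is the only comparison at hand. Compound 3 `COc1ccc(-c2csc(N3N=C(c4ccc(N5CCCCC5)cc4)CC3c3ccc(Cl)cc3)n2)cc1` differs from compound 2 by methoxy in place of chloro on an aromatic carbon. For the measured compounds named here, no measured step involves a methoxy group, and the one known step ran from fluoro to chloro rather than from chloro onward, so it cannot be carried over directly; it shows only that the group on this ring para to a large group shifts the read-out of this assay. With compound 2 standing at a limit, a move in either direction from it remains possible. Compound 3 is estimated to give about 60000 nM in this assay, within a range from 15000 nM to 150000 nM. This would mean an expected step of an at least 1.6-fold lower number from compound 2 to compound 3 (0.22 log units; that floor lies within the scatter).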

Compound 3, half-maximal inhibitory concentration: > 100000 nM
Compound 3: a limit, no number; the forecaster's own chance of this, stated with the estimate: 45%; at least 1.6-fold (0.22 log units) between middle value and limit.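

In this assay, methoxy in place of fluoro on this aromatic carbon gives an at least 4.3-fold higher number from compound 1 to compound 3 (0.63 log units; beyond the scatter), so compound 1 now stands apart from two different replacements rather than one. Of the three compounds shown, only compound 1, with fluoro, gives a number, while compound 2 and compound 3 are both reported only as limits. The step between compound 2 and compound 3 cannot be read, because both sit at the same limit: the limit of > 100000 nM in this assay, at which 2 of the 3 values shown sit.

As far as these compounds go, how compound 2 and compound 3 rank against each other stays open, as does how far beyond the limit either lies. Also open, from the compounds shown here alone, is whether fluoro is unusual at this position or whether other groups, such as a plain hydrogen, a nitrile or an amine, would also give a number in this assay.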